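Swapping a nitrile for a cyanosulfanyl group on a side chain

The source may hold more compounds than are shown below. What is called first, only, known or untested is meant among the compounds shown, and "the series" means these compounds.

Measured so far:
- compound 1, `NCCCCc1c[nH]c2c(F)cccc12`: 21 nM
- compound 2, `N#CCCCc1c[nH]c2ccc(F)cc12`: 72 nM
- compound 3, `N#CCCCc1c[nH]c2ccc(C(=O)O)cc12`: "not active" (no number reported), with no number given

All three compounds were tested in an assay on isolated protein for inhibition of Myeloperoxidase (Homo sapiens), read by ELISA, with a stated time of 5 min; on this read-out higher numbers stand for weaker inhibition and lower numbers for stronger inhibition. Among the two that returned a number, compound 2 holds the higher one; compound 1 gives 21 nM, and the gap between the two lies beyond the usual scatter. Compound 3 produced no number at all, so it offers no point of comparison on this scale.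

Compound 4, `N#CSCCCc1c[nH]c2ccc(F)cc12`, has not yet been measured. It differs from compound 2 in one place: cyanosulfanyl in place of cyano on a saturated chain carbon, three bonds along the chain from an aromatic carbon. Among the measured compounds shown here, no measured pair shows this particular change, so there is no step from the data to lean on. With the nitrile kept and only a sulfur atom inserted before it, the expectation for this assay is a small step, more likely toward a somewhat higher number than a lower one, and not far beyond the scatter.

Compound 4 is therefore expected to give about 120 nM. For compound 4 the expected range runs from 30 nM to 500 nM. The step this estimate implies is a 1.7-fold higher number from compound 2 to compound 4 (0.22 log units; within the scatter).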

Compound 4, half-maximal inhibitory concentration: 23 nM
Beside the measured number, compound 4's estimate is 5.2-fold (0.72 log units) above it, and the stated range ends above it.
By their numbers in this assay, from the lowest: compounds 1 and 4 (each within the scatter of the next); then compound 2.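

In this assay putting a sulfur atom in front of the nitrile gives a 3.1-fold lower number from compound 2 to compound 4 (0.50 log units; beyond the scatter) and so provides the first measured sign that the end of this side chain can be changed without losing inhibition. The step is modest but lies beyond the usual scatter, which means that cyanosulfanyl in place of cyano, on a saturated chain carbon, three bonds along the chain from an aromatic carbon, moves the number toward stronger inhibition in this pair. The data shown contain no measurement that bears on why the number falls.

This single pair cannot tell whether the sulfur atom itself matters or whether any extra atom in that place would do the same, so a longer chain with a plain carbon there, or an oxygen atom in place of the sulfur, would separate the two readings. On these data alone, it also remains open whether the same swap gives a similar step on a core carrying a chloro group in place of the fluorine.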